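The compounds below may be only part of what the source reports. "The series", "measured", "known", "first", "only" and "open" are said of these compounds alone.

Three ureas built on one shared core have been tested in an ADME assay on HEK293 cells (Homo sapiens) for cytotoxicity, with a stated time of 72 h; on this read-out higher numbers stand for an effect only at larger amounts of compound and lower numbers for an effect already at smaller amounts. Compound 1 `Cc1cc(NC(=O)Nc2ccccc2C(F)(F)F)c2ccccc2n1` carries a trifluoromethyl group, and in this assay compound 1 gives > 25000 nM, which is a limit of the assay and not a number. Compound 2 `Cc1cc(NC(=O)Nc2ccccc2F)c2ccccc2n1` carries a fluoro group instead, and in this assay compound 2 gives > 25000 nM, again a limit. Compound 3 `Cc1cc(NC(=O)Nc2ccccc2OC(F)(F)F)c2ccccc2n1` carries a trifluoromethoxy group, and in this assay compound 3 gives > 25000 nM, also a limit. Compound 3 thus stands at the limit of > 25000 nM in this assay, at which 3 of the 3 values shown sit. The steps among these compounds, a step that the two limits leave unreadable from compound 1 to compound 2, a step that the two limits leave unreadable from compound 1 to compound 3 and a step that the two limits leave unreadable from compound 2 to compound 3, cannot be sized. Compound 4 `Cc1cc(NC(=O)Nc2ccccc2C(N)=O)c2ccccc2n1` differs from compound 3 by carbamoyl in place of trifluoromethoxy on an aromatic carbon. Going by the values given here, no measured step offers a readable size or direction for this change, so the expected step, a step that the limit leaves unreadable from compound 3 to compound 4, is set at none beyond the scatter. Compound 4 is therefore estimated at 30000 nM, within a range from 12000 nM to 100000 nM, and most likely reported again only as a limit.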

Compound 4, half-maximal effective concentration: > 25000 nM
Compound 4 was reported as a limit (the forecaster's own chance of this, stated with the estimate: 80%); the middle value is on the limit's open side.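

No step from compound 1, compound 2 or compound 3 to compound 4 can be read in this assay, as each value is a limit and not a number: the limit of > 25000 nM in this assay, at which 4 of the 4 values shown sit.

The compounds shown leave open at what amount any of these four ureas would affect the cells, and whether the group on the aromatic carbon matters at all.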